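Isobutyl in place of sec-butyl, tested a second time

This account rests on a few compounds, and the source may have more. Where it says the series, first, only, none or still open, it means among the compounds named here.

Compound 1 `Cc1nc2ccccc2nc1Oc1ccc(C(=O)N[C@@H](CC(C)C)C(=O)O)cc1`: 17300 nM
Compound 2 `CC[C@@H](C)[C@H](NC(=O)c1ccc(Oc2nc3ccccc3nc2C)cc1)C(=O)O`: 33200 nM
Compound 3 `CC[C@@H](C)[C@H](NC(=O)c1ccc(Oc2nc3ccccc3nc2NC(C)(C)C)cc1)C(=O)OC`: 31900 nM

All three were tested in a functional assay on HeLa cells (Homo sapiens) for antiproliferative activity, read by MTT assay, with a stated time of 48 h; on this read-out lower numbers stand for stronger inhibition and higher numbers for weaker inhibition. Compound 2 differs from compound 1 only by isobutyl in place of sec-butyl on a saturated chain carbon bound to an amide-type nitrogen and a carbonyl carbon, and that change gave a 1.9-fold lower number from compound 2 to compound 1 (0.28 log units; within the scatter). The cores of compound 2 and compound 3 differ in more than one place, so that difference is not broken down here; in this assay compound 3 gives 31900 nM, close to compound 2.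

Compound 4 `COC(=O)[C@H](CC(C)C)NC(=O)c1ccc(Oc2nc3ccccc3nc2NC(C)(C)C)cc1` is not yet measured. It differs from compound 3 by isobutyl in place of sec-butyl on a saturated chain carbon bound to an amide-type nitrogen and a carbonyl carbon, the same change as between compound 2 and compound 1. Because a 1.9-fold lower number from compound 2 to compound 1 (0.28 log units; within the scatter) stayed within the scatter, a step of about a 1.6-fold lower number from compound 3 to compound 4 (0.20 log units; within the scatter) is expected from compound 3 to compound 4. Compound 4 is therefore estimated at 20000 nM, likely between 8000 nM and 50000 nM.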

Compound 4, half-maximal inhibitory concentration: > 50000 nM
Compound 4: no number, only a limit; the forecaster's own chance of this, stated with the estimate: 10%; at least 2.5-fold (0.39 log units) between middle value and limit.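

In this assay compound 4 gives only a limit of the assay, > 50000 nM, and not a number. Isobutyl in place of sec-butyl gives an at least 1.5-fold higher number from compound 3 to compound 4 (0.19 log units; that floor lies within the scatter), and this change does not carry over as the same step from one core to the other: the same change on two cores in this assay, a 1.9-fold lower number (0.28 log units; within the scatter) from compound 2 to compound 1 and an at least 1.5-fold higher number (0.19 log units; that floor lies within the scatter) from compound 3 to compound 4, at least 3.0-fold (0.47 log units) apart, beyond the scatter of two such steps This rests on a single pair of cores, and it does not show which difference in the cores matters or how large the gap truly is.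

The compounds shown leave open how the change behaves with the carboxylic acid and the tert-butylamino group on one core. They also leave open what a primary amide in place of the methyl ester, or a longer chain in place of isobutyl, would give.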